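The compounds below may be only part of what the source reports. "The series", "measured", "known", "first", "only" and "open" are said of these compounds alone.

Compound 3 `Cc1cc(-c2c(F)cc3c(=O)c(Cc4ccc(Cl)cc4)cn(C4CC4)c3c2F)cc(C)n1` gives 20000 nM in a functional assay on P388 cells (Mus musculus) for cytotoxicity; on this read-out lower numbers stand for stronger inhibition and higher numbers for weaker inhibition. Within the three measured compounds it stands level with compound 2 `COc1cccc(Cc2cn(C3CC3)c3c(F)c(-c4cc(C)nc(C)c4)c(F)cc3c2=O)c1`, which gives 20000 nM, and the step of no change at the digits printed from compound 2 to compound 3 (within the scatter). Compound 1 `Cc1cc(-c2c(F)cc3c(=O)ccn(C4CC4)c3c2F)cc(C)n1` gives 15000 nM, with the steps of a 1.3-fold higher number from compound 1 to compound 2 (0.12 log units; within the scatter) and a 1.3-fold higher number from compound 1 to compound 3 (0.12 log units; within the scatter).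

Compound 4 `Cc1cc(-c2c(F)cc3c(=O)c(Cc4ccc[nH]4)cn(C4CC4)c3c2F)cc(C)n1` differs from compound 3 by 1H-pyrrol-2-yl in place of 4-chlorophenyl on a saturated chain carbon bound to an aromatic carbon.

The step bearing most on this change is no change at the digits printed from compound 2 to compound 3 (within the scatter), an exchange of one aromatic group for another on the same saturated chain carbon, which stayed within the scatter. Adding either benzyl group to compound 1 also stayed within the scatter. No step beyond the scatter in this assay is therefore expected, no change at the digits printed from compound 3 to compound 4 (within the scatter). Compound 4 is estimated at 20000 nM, within 8000 nM to 50000 nM.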

Compound 4, half-maximal inhibitory concentration: 930 nM
Compound 4: the middle estimate sits 22-fold (1.33 log units) above what was measured; measured number below the stated range.
By their numbers in this assay, from the lowest: compound 4; then compounds 1, 2 and 3 (each within the scatter of the next).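

In this assay the group on the saturated chain carbon does matter: 1H-pyrrol-2-yl in place of 4-chlorophenyl gives a 22-fold lower number from compound 3 to compound 4 (1.33 log units; beyond the scatter) and in place of 3-methoxyphenyl gives a 22-fold lower number from compound 2 to compound 4 (1.33 log units; beyond the scatter) although those two aryl groups stood level. Set against hydrogen, (1H-pyrrol-2-yl)methyl gives a 16-fold lower number from compound 1 to compound 4 (1.21 log units; beyond the scatter) where both benzyl groups stayed within the scatter. No measurement shown accounts for these steps.

Ring size, heavy-atom count and donor count all change together in compound 4 and remain unseparated. Furan-2-yl or 1-methyl-1H-pyrrol-2-yl on the same saturated chain carbon remains open.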